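The compounds below may be only part of what the source reports. "The series", "measured", "known", "first", "only" and "open" are said of these compounds alone.

Of the compounds shown here, two have so far been measured in a functional assay, with a stated time of 20 min; on this read-out lower numbers stand for stronger inhibition and higher numbers for weaker inhibition. Compound 1, with the structure `COc1ccc(-c2nc(SC)n(C)c(=O)c2C#N)cc1`, gives 58 ug/mL in this assay. Compound 2, with the structure `CCOC(=O)c1cnn(-c2nc(-c3ccccc3F)c(C#N)c(=O)n2C)c1N`, gives 69 ug/mL in this assay. Compound 2 carries the higher of the two numbers, but the two values sit within the scatter of repeated measurements of this kind, so no order can be read from them. Among the measured compounds shown here, no two measured compounds differ in a single place, so there is no step of known size to lean on.

Compound 3, with the structure `CCOC(=O)c1cnn(-c2nc(-c3ccccc3Cl)c(C#N)c(=O)n2C)c1N`, has not yet been measured. It differs from compound 2 in one place: chloro in place of fluoro on an aromatic carbon, ortho to a large group. One heavy atom gives way to another, with no ring, no hydrogen-bond donor or acceptor and no net charge involved. Only a small move, in no firm direction and not beyond the scatter, is expected for the step of a 1.2-fold lower number from compound 2 to compound 3 (0.06 log units; within the scatter). Compound 3 is therefore expected to give about 60 ug/mL in this assay, with a range from 25 ug/mL to 150 ug/mL.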

Compound 3, half-maximal inhibitory concentration: 78 ug/mL
Beside the measured number, compound 3's estimate is 1.3-fold (0.11 log units) below it; measured number inside the range.
By their numbers in this assay, from the lowest: compounds 1, 2 and 3 (each within the scatter of the next).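

In this assay, among the compounds shown here, going from 2-fluorophenyl to 2-chlorophenyl gives a 1.1-fold higher number from compound 2 to compound 3 (0.05 log units; within the scatter), which is the first step of known size. For the compounds shown here, earlier, the only comparison was between two compounds that differ in several places, whereas this pair isolates a single change on an aromatic carbon, ortho to a large group. At this one place, and in this one assay, the data give no ground for preferring chloro or fluoro, and no separate measurement is available to bear on this result.

As far as these compounds go, a single exchange of one halogen for another says little about how much this place can tolerate, so it remains open whether a different kind of group here, such as an amine, a carboxylic acid or a longer chain, would produce a step beyond the scatter. Going by these compounds alone, the effect of changes elsewhere on the shared core, such as replacing the ethyl ester, also remains open, as no step at any other place is available.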